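The compounds below may be only part of what the source reports. "The series", "measured", "known", "first", "only" and "open" are said of these compounds alone.

Compound 1 `Cc1ccc2ncc(S(=O)(=O)c3cc(Cl)cc(Cl)c3)c(N3CCC(C)CC3)c2c1` and compound 2 `Cc1ccc(S(=O)(=O)c2cnc3ccc(C)cc3c2N2CCC(C)CC2)cc1` share one core and differ only in the aryl group on the sulfonyl sulfur. In an assay on isolated protein for displacement of a labelled ligand from metabotropic glutamate receptor 5 (Homo sapiens), with a stated time of 60 min, tested at 1 uM (a higher number here means more inhibition at the concentration tested (going by the name of the read-out), a lower number less inhibition), compound 1 gives 75%, and in this assay compound 2 gives 82%; the step of a number 7 percentage points higher from compound 1 to compound 2 (within the scatter) lies within the scatter, so the two compounds cannot be ranked against each other. Compound 3 `Cc1ccc2ncc(S(=O)(=O)c3ccc(C)c(F)c3)c(N3CCC(C)CC3)c2c1` is not yet measured. It differs from compound 2 by fluoro in place of hydrogen on an aromatic carbon. Going by the values given here, only one measured step bears on this: exchanging the whole aryl group on the sulfonyl sulfur, a larger change than adding a single fluorine, stayed within the scatter. No measurement of this fluorine change itself exists. The step to compound 3 is therefore expected to be small, a number 2 percentage points lower from compound 2 to compound 3 (within the scatter), in either direction. Compound 3 is estimated to give 80% in this assay, with an expected range from 62% to 92%.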

Compound 3, a percentage reported as inhibition, at one concentration (the size of the read-out at that concentration, not a potency): 91%
Estimate against measurement, compound 3: 11 percentage points below, within the range that was stated.
By their numbers in this assay, from the lowest: compounds 1, 2 and 3 (each within the scatter of the next, the first and the last beyond it).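

In this assay, fluoro in place of hydrogen on an aromatic carbon, ortho to a methyl group, comes out as a number 9 percentage points higher from compound 2 to compound 3 (within the scatter), so this position accepts a fluoro, though the step is too small to rank the two compounds. Going by these compounds alone, the same fluoro does yield the first step that clears the scatter, a number 16 percentage points higher from compound 1 to compound 3 (beyond the scatter), showing that the choice of aryl group on the sulfonyl sulfur can matter, which the exchange of 3,5-dichlorophenyl for 4-methylphenyl could not show. Nothing available here explains these numbers.

The compounds shown leave open whether a methoxy group or an amine on the same aromatic carbon would give a number beyond the scatter from that of compound 2. They also leave open whether fluoro would give a similar number without the neighbouring methyl group.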